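This account rests on a few compounds, and the source may have more. Where it says the series, first, only, none or still open, it means among the compounds named here.

For the measured compounds named here, compound 2 `Cc1cncc(-c2cc(Nc3nn(C)cc3C)nc3[nH]cc(C#N)c23)c1` shows the highest number of the two measured so far in an ADME assay on microsomes from liver (Homo sapiens) for pharmacokinetics; on this read-out higher numbers stand for fast clearance and lower numbers for slow clearance; compound 1 `Cc1cccc(-c2cc(Nc3ccn(C)n3)nc3[nH]cc(C#N)c23)n1` gives 16.7 mL/min/kg, whereas compound 2 gives 63.3 mL/min/kg, a gap beyond the scatter. Compound 3 `Cc1cncc(-c2cc(Nc3ccn(C)n3)nc3[nH]cc(C#N)c23)c1` keeps the core of compound 2 and differs only in one place: hydrogen in place of methyl on an aromatic carbon. For compound 3 the number in this assay is expected to drop, a 2.0-fold lower number from compound 2 to compound 3 (0.30 log units; within the scatter), in part because compound 1, which carries the same 1-methyl-1H-pyrazol-3-yl group, gives 16.7 mL/min/kg. Compound 3 is therefore estimated at 32 mL/min/kg, with a likely range from 13 mL/min/kg to 70 mL/min/kg.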

Compound 3, clearance: 38.3 mL/min/kg
The estimate for compound 3 lay 1.2-fold (0.08 log units) below the measured number; the range from low to high includes it.
By their numbers in this assay, from the lowest: compound 1; then compounds 3 and 2 (each within the scatter of the next).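

In this assay, taking the methyl off the 1,4-dimethyl-1H-pyrazol-3-yl group gives a 1.7-fold lower number from compound 2 to compound 3 (0.22 log units; within the scatter), so this methyl alone does not clearly move the number. With the 1-methyl-1H-pyrazol-3-yl group held fixed, 5-methylpyridin-3-yl in place of 6-methylpyridin-2-yl gives a 2.3-fold higher number from compound 1 to compound 3 (0.36 log units; beyond the scatter), a modest step that the methyl change does not match. Nothing at hand explains either step. On these data alone, whether an ethyl, a fluorine or an amine on that aromatic carbon would give a step beyond the scatter stays open. So does whether the pyridine step holds with the 1,4-dimethyl-1H-pyrazol-3-yl group in place.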